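A few compounds are considered here, and "the series" means these few. Any claim that something is new, unique, unknown or untested is made for them only; others in the source may bear on it.

Measured so far:
- compound 1, `COc1cc(-c2cc(/C=C/C(=O)c3ccc(N)cc3)[nH]n2)cc(OC)c1OC`, 3670 nM
- compound 2, `COc1ccc(-c2cc(/C=C/C(=O)c3cc(OC)c(OC)c(OC)c3)[nH]n2)cc1OC`, 2820 nM
- compound 3, `COc1ccc(-c2cc(/C=C/C(=O)c3ccc(N)cc3)[nH]n2)cc1`, 10600 nM

These three compounds were tested in a functional assay on ACHN cells (Homo sapiens) for inhibition, read by sulforhodamine B assay, with a stated time of 48 h; a lower number here means a stronger inhibitor of growth, a higher number a weaker inhibitor of growth. Among the three numbers, compound 1 stands second highest. Its nearest neighbour is compound 2, whose value lies within the usual scatter of compound 1, so the two cannot be told apart on this evidence. Compound 3 lies furthest away, with a clearly higher number than compound 1, a gap beyond the scatter.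

Compound 4, `COc1cc(-c2cc(/C=C/C(=O)c3ccc(F)c(F)c3)[nH]n2)cc(OC)c1OC`, has not yet been measured in this assay. It differs from compound 1 in one place: 3,4-difluorophenyl in place of 4-aminophenyl on a carbonyl carbon. Compound 1 and compound 2 show that rather different groups on the carbonyl carbon give numbers that cannot be separated, while compound 3 shows that a change elsewhere in the molecule can move the number well beyond the scatter. Going by the values given here, no step between measured compounds isolates the group on the carbonyl carbon, so the direction is uncertain. The step from compound 1 to compound 4 in this assay is expected to be small, a 1.1-fold lower number from compound 1 to compound 4 (0.06 log units; within the scatter), possibly none beyond the scatter. Compound 4 is therefore estimated at 3200 nM, with a range from 900 nM to 11000 nM.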

Compound 4, concentration for total growth inhibition: > 100000 nM
Compound 4 was reported as a limit (the forecaster's own chance of this, stated with the estimate: 5%); middle value at least 31-fold (1.49 log units) from the limit.
By their numbers in this assay, from the lowest: compounds 2 and 1 (each within the scatter of the next); then compound 3. At a limit, above all of these: compound 4.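

In this assay, putting 3,4-difluorophenyl in place of 4-aminophenyl on a carbonyl carbon gives an at least 27-fold higher number from compound 1 to compound 4 (1.43 log units; beyond the scatter). This is the first step shown that changes only this group, and it shows that the group on the carbonyl carbon can matter greatly: with the rest of compound 1 unchanged, this single replacement takes the number far beyond the scatter. On these data alone, the true size of the step remains unknown, since compound 4 is reported only as a limit and not as a number: the limit of > 100000 nM in this assay, at which 1 of the 4 values shown sits.

The step removes the 4-aminophenyl group and introduces the 3,4-difluorophenyl group in one move, so it cannot say whether the amine matters, the two fluorines matter, or both do. Unsubstituted phenyl, 4-fluorophenyl or 4-hydroxyphenyl on the carbonyl carbon could help separate these possibilities, and it also remains open whether the same replacement would have as large an effect with the different methoxy pattern of compound 3.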